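The compounds below may be only part of what the source reports. "The series", "measured", "known", "first", "only" and "open" are said of these compounds alone.

Working notes on the series. In a functional assay on PC-3 cells (Homo sapiens) for cytotoxicity, read by sulforhodamine B assay, with a stated time of 48 h (on this read-out lower numbers stand for stronger inhibition and higher numbers for weaker inhibition), compound 1 `C[C@H]1CC[C@@H]2[C@@H](OC(=O)[C@]23CC(c2c(Cl)cccc2Cl)=NO3)[C@]2(C)C(=O)C=C[C@@]12O` gives 56000 nM. On the same read-out compound 2 `C[C@H]1CC[C@@H]2[C@@H](OC(=O)[C@]23CC(c2ccccc2[N+](=O)[O-])=NO3)[C@]2(C)C(=O)C=C[C@@]12O` gives 37000 nM. Among the measured compounds shown here, these two numbers lie within the scatter of each other, so compound 2 stands level with the only other measured compound.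

Compound 3 `COc1cc(C2=NO[C@]3(C2)C(=O)O[C@@H]2[C@H]3CC[C@H](C)[C@]3(O)C=CC(=O)[C@@]23C)ccc1O` keeps the shared core and differs from compound 2 in one place: 4-hydroxy-3-methoxyphenyl in place of 2-nitrophenyl on a carbon with a double bond to nitrogen. The change is 4-hydroxy-3-methoxyphenyl in place of 2-nitrophenyl on a carbon with a double bond to nitrogen, in the five-membered non-aromatic ring with 1 nitrogen and 1 oxygen.

For the measured compounds named here, one measured step bears on this place: a 1.5-fold lower number from compound 1 to compound 2 (0.18 log units; within the scatter). It also exchanges one substituted phenyl for another on that carbon, and it stays within the scatter. Going by the values given here, no measured compound carries a hydroxy or methoxy group on this phenyl, so the evidence is thin and the range must stay wide. In this assay no step beyond the scatter is therefore expected, in either direction.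

The expected change is a 1.1-fold higher number from compound 2 to compound 3 (0.03 log units; within the scatter). Compound 3 is estimated at 40000 nM, with an expected range of 15000 nM to 100000 nM.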

Compound 3, half-maximal inhibitory concentration: 16000 nM
Beside the measured number, compound 3's estimate is 2.5-fold (0.40 log units) above it, within the range that was stated.
By their numbers in this assay, from the lowest: compound 3; then compounds 2 and 1 (each within the scatter of the next).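

In this assay the position on a carbon with a double bond to nitrogen now gives steps beyond the scatter, both modest: a 2.3-fold lower number from compound 2 to compound 3 (0.36 log units; beyond the scatter) and a 3.5-fold lower number from compound 1 to compound 3 (0.54 log units; beyond the scatter), whereas 2-nitrophenyl in place of 2,6-dichlorophenyl had stayed within it. The choice of substituted phenyl at this place can therefore move the read-out, and 4-hydroxy-3-methoxyphenyl separates from the other two groups, with 1 hydrogen-bond donor against 0 in 2-nitrophenyl and the same count of 9 heavy atoms. No measurement at hand explains the step, and the two structures alone cannot tell whether it belongs to the hydroxy group, the methoxy group or the departure of the nitro group.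

Still open, going by these compounds, is whether a phenyl carrying only the hydroxy group or only the methoxy group would match compound 3 or fall back level with compound 2. Also open, on these data alone, is how an amine or a carboxylic acid on this phenyl, or a longer alkyl chain in its place, would read on the shared core.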